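The source may report more compounds than this note shows. Statements on the series, on what has been measured and on what is new or still open speak of the compounds shown alone.

Of the compounds shown here, three built on a shared core have been tested in a functional assay on A549 cells (Homo sapiens) for cytotoxicity, read by MTT assay, with a stated time of 48 h; a lower number here means a stronger inhibitor, a higher number a weaker inhibitor. Compound 1 `CC(=O)O[C@H]1C=CC(=O)O[C@H]1[C@H]1OC(=O)O[C@@H]1c1ccccc1` reaches only a limit of the assay, > 40000 nM. Compound 3 `CC(=O)O[C@H]1C=CC(=O)O[C@@H]1[C@@H](O)[C@H](O)c1ccccc1` likewise gives nothing more than a limit, > 40000 nM. Two of the three values therefore sit at the limit of > 40000 nM in this assay, at which 2 of the 3 values shown sit. Among the measured compounds shown here, compound 2 `CC(=O)O[C@H]1C=CC(=O)O[C@@H]1c1nc(/C=C/c2ccccc2)oc1-c1ccccc1` is the one member with a measured number: in this assay compound 2 gives 24800 nM, so it stands as the only number among the values shown.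

Compound 4 `C/C=C\c1nc([C@H]2OC(=O)C=C[C@@H]2OC(C)=O)c(-c2ccccc2)o1` differs from compound 2 in a single place, prop-1-en-1-yl in place of 2-phenylethenyl on an aromatic carbon. For the measured compounds named here, no measured pair shows this change, so nothing tells how large a step it brings. Given that compound 2 itself gives 24800 nM, the expected step is a 1.4-fold higher number from compound 2 to compound 4 (0.15 log units; within the scatter), a weakening at most modest, possibly none beyond the scatter. Compound 4 is accordingly estimated at 35000 nM, with a range from 12000 nM to 100000 nM.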

Compound 4, half-maximal inhibitory concentration: > 40000 nM
Compound 4 was reported as a limit (the forecaster's own chance of this, stated with the estimate: 50%); middle value at least 1.1-fold (0.05 log units) from the limit.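

Among the compounds shown here, the change of 2-phenylethenyl to prop-1-en-1-yl, on an aromatic carbon of a five-membered aromatic ring with 1 nitrogen and 1 oxygen, gives the first step that can be read at this position in this assay: an at least 1.6-fold higher number from compound 2 to compound 4 (0.20 log units; that floor lies within the scatter). Since compound 4 gave only a limit, this step is a floor and not a size, so the true change may stay within the scatter or may be much larger. The smaller group, which has no ring, brings no lower number, and only compound 2 still gives a number below the limit: the limit of > 40000 nM in this assay, at which 3 of the 4 values shown sit.

The compounds shown leave open how large the step really is. They also leave open whether another group on this carbon, such as an amine, a carboxylic acid or a longer chain, would give a number in this assay.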